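Fluoro to methylsulfanyl on the aromatic ring

The compounds below may be only part of what the source reports. "The series", "measured", "known", "first", "only" and "open" are said of these compounds alone.

Compound 1 `CSc1ccc(C2=C(c3ccc(O)cc3)C(=O)N3CCCC3C2)cc1`: > 100000 nM, a limit of the assay
Compound 2 `CSc1ccc(C2=C(c3ccc(OCC4CO4)cc3)C(=O)N3CCCC3C2)cc1`: 500 nM
Compound 3 `CSc1ccc(C2=C(c3ccc(F)cc3)C(=O)N3CCCC3C2)cc1`: 100 nM

In a functional assay on A498 cells (Homo sapiens) for cytotoxicity (a higher number here means a weaker inhibitor of growth, a lower number a stronger inhibitor of growth), compound 3 gives 100 nM, the lowest number of the three and so the strongest inhibitor of growth among them. Its nearest neighbour lies one modest step away: a 5.0-fold lower number from compound 2 to compound 3 (0.70 log units; beyond the scatter).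

Compound 4 `CSc1ccc(C2=C(c3ccc(SC)cc3)C(=O)N3CCCC3C2)cc1` has not yet been measured. It differs from compound 3 in one place, with methylsulfanyl in place of fluoro on an aromatic carbon, para to a large group (methylsulfanyl in place of fluoro on an aromatic carbon).

All three measured steps concern this same aromatic carbon. Two are large, an at least 200-fold lower number from compound 1 to compound 2 (2.30 log units; beyond the scatter) and an at least 1000-fold lower number from compound 1 to compound 3 (3.00 log units; beyond the scatter), but both start from a limit and both remove the hydroxy group, which plays no part in the new change. The closer guide is the modest step, a 5.0-fold lower number from compound 2 to compound 3 (0.70 log units; beyond the scatter), where (oxiran-2-yl)methoxy in place of fluoro still leaves compound 2 at 500 nM. Going by the values given here, no measured compound carries methylsulfanyl at this carbon, so the direction is uncertain, though a modest rise in this assay seems the likelier outcome. The expected change is a 2.5-fold higher number from compound 3 to compound 4 (0.40 log units; beyond the scatter). For compound 4 the estimate is 250 nM, with an expected range from 50 nM to 1000 nM.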

Compound 4, concentration for 50% growth inhibition: 15000 nM
Beside the measured number, compound 4's estimate is 60-fold (1.78 log units) below it; the measured number lies above the stated range.
By their numbers in this assay, from the lowest: compound 3; then compound 2; then compound 4. At a limit, above all of these: compound 1.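

In this assay, going by these compounds alone, this aromatic carbon, para to a large group, proves far more sensitive than the one modest step among the earlier compounds suggested, since exchanging fluoro for methylsulfanyl gives a 150-fold higher number from compound 3 to compound 4 (2.18 log units; beyond the scatter), and exchanging (oxiran-2-yl)methoxy for methylsulfanyl gives a 30-fold higher number from compound 2 to compound 4 (1.48 log units; beyond the scatter). Loss of growth inhibition at this carbon is therefore no longer tied to the hydroxy group of compound 1. In compound 4, a group without a hydrogen-bond donor also weakens inhibition sharply. The larger change in heavy atoms does not simply track the result: compound 2 lies closer to compound 3 than compound 4 does. Compound 1 stands at a limit of the assay, > 100000 nM, so an at least 6.6-fold lower number from compound 1 to compound 4 (0.82 log units; beyond the scatter) is only a bound and still places methylsulfanyl on the active side of hydroxy.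

The compounds shown leave open whether a methoxy or a chloro group at this carbon would fall nearer compound 3 or compound 4. They also carry no measurement that would explain why methylsulfanyl differs so much from fluoro here.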